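A few compounds are considered here, and "the series" means these few. Any claim that something is new, unique, unknown or untested is made for them only; others in the source may bear on it.

Working notes on the series. The shared core is carried by compound 1 `Cc1cc(=O)n(-c2cccc(F)c2)nc1C(=O)Nc1ccc(Oc2ncnc3sccc23)cc1`, compound 2 `Cc1ccc(-n2nc(C(=O)Nc3ccc(Oc4ncnc5sccc45)cc3)c(C)cc2=O)cc1`, compound 3 `Cc1cc(=O)n(-c2cccc(F)c2)nc1C(=O)Nc1ccc(Oc2ncnc3sccc23)c(F)c1` and the not yet measured compound 4 `Cc1ccc(-n2nc(C(=O)Nc3ccc(Oc4ncnc5sccc45)c(F)c3)c(C)cc2=O)cc1`. In a functional assay on HepG2 cells (Homo sapiens) for cytotoxicity, read by MTT assay, with a stated time of 72 h (a higher number here means a weaker inhibitor, a lower number a stronger inhibitor), compound 1 gives 18500 nM. In this assay compound 3 gives 24500 nM. For compound 2 the reading in this assay is a limit of the assay rather than a number, > 40000 nM.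

Compound 3 differs from compound 1 by fluoro in place of hydrogen on an aromatic carbon, and the step is a 1.3-fold higher number from compound 1 to compound 3 (0.12 log units; within the scatter).

The change from compound 1 to compound 2 is 4-methylphenyl in place of 3-fluorophenyl on an aromatic nitrogen; it gives an at least 2.1-fold higher number from compound 1 to compound 2 (0.33 log units; beyond the scatter), and the size of this step is known only as a lower bound because of the limit of > 40000 nM in this assay, at which 1 of the 3 values shown sits. The change from compound 3 to compound 4 is the same change, (4-methylphenyl in place of 3-fluorophenyl on an aromatic nitrogen), the two descriptions of the place agreeing word for word.

Because compound 1 moved by an at least 2.1-fold higher number from compound 1 to compound 2 (0.33 log units; beyond the scatter) under this change, compound 4 is expected to move in this assay by at least as much from the starting point of compound 3. The expected step is a 2.4-fold higher number from compound 3 to compound 4 (0.39 log units; beyond the scatter), beside the measured at least 2.1-fold higher number from compound 1 to compound 2 (0.33 log units; beyond the scatter). The estimate for compound 4 in this assay is 60000 nM. The expected range for compound 4 runs from 30000 nM to 150000 nM, with a real chance that only a limit of the assay is returned.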

Compound 4, half-maximal inhibitory concentration: > 40000 nM
Compound 4: no number, only a limit; the forecaster's own chance of this, stated with the estimate: 85%; the middle value lies beyond the limit too.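

In this assay compound 4 reads > 40000 nM, which is a limit of the assay and not a number. On the core of compound 3, the swap of 3-fluorophenyl for 4-methylphenyl gives an at least 1.6-fold higher number from compound 3 to compound 4 (0.21 log units; that floor lies within the scatter), so this floor alone does not establish a real step on this core, and the comparison with the core of compound 1 stands as follows: the same change on two cores in this assay, an at least 2.1-fold higher number (0.33 log units; beyond the scatter) from compound 1 to compound 2 and an at least 1.6-fold higher number (0.21 log units; that floor lies within the scatter) from compound 3 to compound 4; the limit leaves it open whether they differ The result fits a change that carries over from one core to the other but does not show how far it does, since neither step has a known full size and the fluoro step between the two limit compounds, compound 2 and compound 4, cannot be read: the limit of > 40000 nM in this assay, at which 2 of the 4 values shown sit.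

The compounds shown leave open how far compound 2 and compound 4 lie past the limit, and so whether fluoro on the aromatic carbon alters the effect of the change at all. Also open is how this assay would read with an amine or a carboxylic acid in place of the methyl group of 4-methylphenyl, a swap that would test the same place with a group quite unlike the two shown there.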